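The compounds below may be only part of what the source reports. "The series", "measured", "known", "first", "only" and "open" are said of these compounds alone.

Compounds measured in a functional assay on HeLa cells (Homo sapiens) for antiproliferative activity, read by MTT assay, with a stated time of 72 h; on this read-out higher numbers stand for weaker inhibition and lower numbers for stronger inhibition:
Compound 1 `COc1ncc(-c2ccc3c(c2)N(c2ccc(C)cc2)C(=O)CO3)cc1NS(=O)(=O)c1ccc(F)cc1` gives 4650 nM.
Compound 2 `COc1ccc(N2C(=O)COc3ccc(-c4cnc5ccccc5c4)cc32)cc1` gives only a limit of this assay, > 40000 nM.
Compound 3 `O=C1COc2ccc(-c3cnc4ccccc4c3)cc2N1c1ccccc1` gives only a limit of this assay, > 40000 nM.

Going by the values given here, compound 1 therefore holds the only number among the three, the other two sitting at the limit of > 40000 nM in this assay, at which 2 of the 3 values shown sit. Among the compounds with values here, the single measured step, a step that the two limits leave unreadable from compound 2 to compound 3, runs between two limits and its size cannot be read. Compound 4 `COc1ncc(-c2ccc3c(c2)N(c2ccc(F)cc2)C(=O)CO3)cc1NS(=O)(=O)c1ccc(F)cc1` differs from compound 1 by fluoro in place of methyl on an aromatic carbon. Within the data shown here, no measured step covers this change, so no direction beyond the scatter is expected. Compound 4 is estimated at 5000 nM, between 2000 nM and 15000 nM. The expected step of a 1.1-fold higher number from compound 1 to compound 4 (0.03 log units; within the scatter) thus stays within the scatter of this assay.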

Compound 4, half-maximal inhibitory concentration: 10500 nM
Beside the measured number, compound 4's estimate is 2.1-fold (0.32 log units) below it; measured number inside the range.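

In this assay, going by these compounds alone, going from 4-methylphenyl to 4-fluorophenyl gives a 2.3-fold higher number from compound 1 to compound 4 (0.35 log units; beyond the scatter), the first readable step in this set, so the group at this place, para to a large group, does affect the read-out. Fluoro in place of methyl weakens inhibition only modestly, and compound 4 still gives a number rather than a limit. Nothing shown here accounts for the size of this step. The compounds shown leave open how a chloro, a trifluoromethyl or an amine at this place would compare with compound 1 and compound 4.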